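A few compounds are considered here, and "the series" means these few. Any claim that something is new, unique, unknown or untested is made for them only; others in the source may bear on it.

Measured so far in a functional assay on A549 cells (Homo sapiens) for cytotoxicity, read by MTT assay, with a stated time of 72 h; a higher number here means a weaker inhibitor, a lower number a stronger inhibitor:

compound 1 `COc1cc2ncnc(Nc3ccc(F)c(Cl)c3)c2cc1NC(=O)/C=C/c1ccc(F)cc1Cl`, compound 1 gives "not active" (no number reported)
compound 2 `COc1cc2ncnc(Nc3ccc(F)c(Cl)c3)c2cc1NC(=O)/C=C/c1ccccc1[N+](=O)[O-]`, compound 2 gives 33300 nM

Going by the values given here, compound 2 stands as the only compound with a number in this assay; compound 1 returned no number at all, so the two cannot be set against each other as a measured step. Both share the same core, and both show that this series does little against these cells at the concentrations tested.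

Compound 3 `COc1cc2ncnc(Nc3ccc(F)c(Cl)c3)c2cc1NC(=O)/C=C/c1ccc(C#N)cc1` differs from compound 2 in one place: 4-cyanophenyl in place of 2-nitrophenyl on a double-bonded chain carbon bound to a double-bonded chain carbon. Among the compounds with values here, no measured step of this kind is available, so the expectation rests on the weak numbers already in hand. The change is expected to make no difference beyond the usual scatter, in either direction, and there is a real chance that compound 3 will return no number at all, as compound 1 did. Compound 3 is estimated at 40000 nM, with a range from 10000 nM to 150000 nM. The expected step of a 1.2-fold higher number from compound 2 to compound 3 (0.08 log units; within the scatter) is therefore essentially flat.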

Compound 3, half-maximal inhibitory concentration: "not active" (no number reported)
Compound 3 has no reported number here; there is nothing to compare the estimate with.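

Compound 3, like compound 1, gave no number in this assay, so no step can be read between compound 2 and compound 3. This leaves open whether exchanging 2-nitrophenyl for 4-cyanophenyl changes the effect on these cells at all, since only compound 2 has a number. No measured evidence bears on this result.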